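The source may hold more compounds than are shown below. What is called first, only, known or untested is meant among the compounds shown, and "the series" means these compounds.

Within the data shown here, compound 1, `Cc1ccc(-c2nn(-c3ccccc3)cc2CNc2ccc(Br)cc2)cc1`, is one of two compounds measured in a functional assay on MCF7 cells (Homo sapiens) for antiproliferative activity, read by MTT assay, with a stated time of 48 h (on this read-out lower numbers stand for stronger inhibition and higher numbers for weaker inhibition), where compound 1 gives 6890 nM. Its companion, compound 2, `Brc1ccc(NCc2cn(-c3ccccc3)nc2-c2ccc(Br)cc2)cc1`, gives 5000 nM in this assay. Among the measured compounds shown here, the only measured step, a 1.4-fold lower number from compound 1 to compound 2 (0.14 log units; within the scatter), separates the two, so compound 1 stands with the higher of the two numbers, though the gap to compound 2 is within the scatter. The unmeasured compound 3, `Cc1ccc(-c2nn(-c3ccccc3)cc2CNc2ccc(Cl)cc2)cc1`, differs from compound 1 in one place: chloro in place of bromo on an aromatic carbon. For the measured compounds named here, no measured step covers this exchange of one halogen for another; the single known step concerns a different group on a different part of the molecule and is itself within the scatter. There is therefore no basis to expect a change beyond the scatter, and compound 3 is estimated to give 7000 nM, within 3000 nM to 16000 nM, an expected step of a 1.0-fold higher number from compound 1 to compound 3 (0.01 log units; within the scatter).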

Compound 3, half-maximal inhibitory concentration: 6020 nM
Estimate against measurement, compound 3: 1.2-fold (0.07 log units) above, and the stated range covers the measured number.
By their numbers in this assay, from the lowest: compounds 2, 3 and 1 (each within the scatter of the next).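

Among these compounds, the only earlier step changed a group elsewhere in the molecule, so this is the first look at the 4-bromophenyl part. In this assay, chloro in place of bromo gives a 1.1-fold lower number from compound 1 to compound 3 (0.06 log units; within the scatter), so at this place, para to a large group, this exchange of one halogen for the other leaves no difference that can be told from the scatter. No evidence is available on what lies behind this result.

Bromo and chloro each enter as a single heavy atom, so it remains open whether a larger or very different group here, such as an amine, a methoxy group or a carboxylic acid, would move the number beyond the scatter. On these data alone, it also remains open whether the same exchange would read alike on compound 2.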